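A few compounds are considered here, and "the series" means these few. Any claim that something is new, unique, unknown or untested is made for them only; others in the source may bear on it.

In an ADME assay on S9 fraction from liver (Mus musculus, strain ICR/CD-1) for metabolic stability, read by LC-MS, using NADPH, with a stated time of 5 min, tested at 2 uM (on this read-out higher numbers stand for a longer-lived compound and lower numbers for a shorter-lived compound), three compounds sharing a sulfonyl-linked core have been measured. Compound 1 (`COc1ccccc1-c1cccc(S(=O)(=O)N2CCC(N3CCC(C)CC3)CC2)c1`) gives 0.25 h, the highest of the three numbers, and its gap to each of the other two lies beyond the scatter. Compound 2 (`CC1CCN(C2CCN(S(=O)(=O)c3ccc(Br)cc3OC(F)(F)F)CC2)CC1`), which carries bromine and trifluoromethoxy groups, gives 0.0833 h. Compound 3 (`Cc1cc(S(=O)(=O)N2CCC(N3CCC(C)CC3)CC2)c(Cl)cc1Cl`), which carries two chlorines and a methyl group, gives 0.108 h.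

Compound 4 (`CC1CCN(C2CCN(S(=O)(=O)c3cccc(-c4ccc(Cl)cc4)c3)CC2)CC1`) has not yet been measured. It has 4-chlorophenyl in place of 2-methoxyphenyl on an aromatic carbon of compound 1: 4-chlorophenyl in place of 2-methoxyphenyl on an aromatic carbon. Within the data shown here, no step between measured compounds isolates this kind of change, so the expectation rests on the three values alone. The halogen-bearing compound 3 at 0.108 h gives some reason to expect a modest fall rather than a rise, though one that stays within the scatter. The expected change is a 1.6-fold lower number from compound 1 to compound 4 (0.19 log units; within the scatter). For compound 4, the estimated half-life is 0.16 h, with an expected range from 0.08 h to 0.33 h.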

Compound 4, half-life: 2.45 h
Compound 4: middle estimate off by 15-fold (1.19 log units), on the low side; measured number outside the range, above it.
By their numbers in this assay, from the lowest: compounds 2 and 3 (each within the scatter of the next); then compound 1; then compound 4.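

In this assay, 4-chlorophenyl in place of 2-methoxyphenyl on the aromatic carbon meta to a large group brings a 9.8-fold higher number from compound 1 to compound 4 (0.99 log units; beyond the scatter) with the rest of the structure unchanged. Among these compounds, this is the only step here that isolates one place, and it shows that the aryl group at this position alone can shift the half-life beyond the scatter. Nothing available bears on the reason for this rise.

Among the compounds shown here, the single step cannot tell whether the higher number goes with the chlorine that enters, the methoxy group that leaves, or both. A plain phenyl ring at this position would help separate the two, while a pyridine ring would show whether the rise holds when the carbon-only aromatic ring changes.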